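Removing the Methoxy from the Benzyl Group of Compound 3

The source may hold more compounds than are shown below. What is called first, only, known or untested is meant among the compounds shown, and "the series" means these compounds.

Compound 3 `COC(=O)C1=C(O)C[C@H](c2ccccn2)N(Cc2ccc(OC)cc2)[C@@H]1c1ccccn1` sits beside compound 1 `C=CCN1[C@@H](c2ccccn2)CC(O)=C(C(=O)OC)[C@H]1c1ccccn1` among the two numbers measured in an ADME assay on J774.1 cells (Mus musculus) for cytotoxicity, with a stated time of 48 h; on this read-out lower numbers stand for an effect already at smaller amounts and higher numbers for an effect only at larger amounts of compound: compound 3 gives 29.9 uM, and compound 1 gives 35 uM, a gap within the scatter. Compound 2 `C[C@@H]1CC2(C[C@H](C)N1)C(=O)N(CCO)C(=O)N2Cc1ccccc1` reached only a limit of the assay, > 100 uM. Compound 4 `COC(=O)C1=C(O)C[C@H](c2ccccn2)N(Cc2ccccc2)[C@@H]1c1ccccn1` differs from compound 3 by hydrogen in place of methoxy on an aromatic carbon. Going by the values given here, the only measured step touching this part of the molecule is a 1.2-fold lower number from compound 1 to compound 3 (0.07 log units; within the scatter), and it left the number within the scatter. A further trimming of the same group is therefore expected to produce no step beyond the scatter, with a 1.0-fold higher number from compound 3 to compound 4 (0.00 log units; within the scatter) as the estimate. Compound 4 is estimated to give 30 uM, within a range from 15 uM to 60 uM.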

Compound 4, concentration for half-maximal effect: 33.2 uM
Beside the measured number, compound 4's estimate is 1.1-fold (0.04 log units) below it; low and high end bracket the measured number.
By their numbers in this assay, from the lowest: compounds 3, 4 and 1 (each within the scatter of the next). At a limit, above all of these: compound 2.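

In this assay, removing the methoxy from the 4-methoxybenzyl group leaves the number within the scatter (a 1.1-fold higher number from compound 3 to compound 4 (0.05 log units; within the scatter)). This adds a change on the aromatic ring itself to the earlier swap of the whole nitrogen substituent, and the plain benzyl compound also stays within the scatter of the vinyl-bearing one (a 1.1-fold lower number from compound 1 to compound 4 (0.02 log units; within the scatter)). Still open, from the compounds shown here alone, is whether an amine or a carboxylic acid on that same aromatic carbon, or a longer chain on the ring nitrogen, would move the number beyond the scatter. Nothing measured here gives a reason for these small steps.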